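This account rests on a few compounds, and the source may have more. Where it says the series, first, only, none or still open, it means among the compounds named here.

Compound 3 `C[C@H]1CN(c2ncc(C(=O)NCC3CCCCC3)cc2Cl)CCN1C1CCN(Cc2ccc(Cl)cc2)CC1` gives the lowest number among the three measured in a functional assay for antagonist activity at C-X-C chemokine receptor type 3 (Homo sapiens); a lower number here means a stronger inhibitor, a higher number a weaker inhibitor: compound 3 gives 2.4 nM, whereas compound 2 `C[C@H]1CN(c2ncc(C(=N)N)cc2Cl)CCN1C1CCN(Cc2ccc(Cl)cc2)CC1` gives 80 nM and compound 1 `CC(=O)c1cnc(N2CCN(C3CCN(Cc4ccc(Cl)cc4)CC3)[C@@H](C)C2)c(Cl)c1` gives 520 nM. Compound 4 `C[C@H]1CN(c2ncc(C(=O)N3CCCCC3)cc2Cl)CCN1C1CCN(Cc2ccc(Cl)cc2)CC1` differs from compound 3 by piperidin-1-yl in place of (cyclohexylmethyl)amino on a carbonyl carbon. The measured steps that bear on this position are large: a 220-fold lower number from compound 1 to compound 3 (2.34 log units; beyond the scatter) and a 33-fold lower number from compound 2 to compound 3 (1.52 log units; beyond the scatter), both showing that the group on this carbonyl carbon carries much of the potency. Compound 4 keeps a six-membered ring at that position but loses the hydrogen-bond donor, so a modest rise in this assay is expected, a 4.2-fold higher number from compound 3 to compound 4 (0.62 log units; beyond the scatter). Compound 4 is therefore estimated at 10 nM, with a range from 3 nM to 40 nM.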

Compound 4, half-maximal inhibitory concentration: 900 nM
The estimate for compound 4 lay 90-fold (1.95 log units) below the measured number; the whole stated range lies below it.
By their numbers in this assay, from the lowest: compound 3; then compound 2; then compounds 1 and 4 (each within the scatter of the next).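

In this assay, a six-membered ring on the carbonyl carbon does not by itself preserve potency: piperidin-1-yl cannot replace (cyclohexylmethyl)amino (a 380-fold higher number from compound 3 to compound 4 (2.57 log units; beyond the scatter)). It also compares poorly with the group in compound 2 (an 11-fold higher number from compound 2 to compound 4 (1.05 log units; beyond the scatter)) and stands level with methyl within the scatter (a 1.7-fold higher number from compound 1 to compound 4 (0.24 log units; within the scatter)), so the potency of compound 3 depends on more than ring size. No available evidence explains this loss.

The compounds shown leave open whether the amide hydrogen or the ring's spacing from the amide matters more. Cyclohexylamino and (2-cyclohexylethyl)amino on the carbonyl carbon would help separate the two.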